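This account rests on a few compounds, and the source may have more. Where it says the series, first, only, none or still open, it means among the compounds named here.

Working notes on the series.

All three measured compounds share one core, seen in compound 1 `O=C1NC(=O)C(Cc2ccc(Oc3ccc(Cl)cc3)cc2)S1`. In a functional assay for agonist activity at Free fatty acid receptor 1 (Homo sapiens), read by FLIPR, in the presence of a further agent that is not named here (on this read-out lower numbers stand for an effect already at smaller amounts and higher numbers for an effect only at larger amounts of compound), compound 1 gives 240 nM, which places it second highest of the three numbers. Compound 2 `O=C1NC(=O)C(Cc2ccc(Oc3ncc(Cl)cc3Cl)cc2)S1` carries a different aryl on the ether oxygen and in this assay compound 2 gives 90 nM, a lower number than compound 1 by a gap beyond the scatter. Compound 3 `O=C1NC(=O)C(Cc2ccc(-c3ccccc3)cc2)S1` has no ether oxygen at all, and in this assay compound 3 gives 2220 nM, the highest number of the set, well beyond the scatter from compound 1.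

Compound 4 `O=C1NC(=O)C(Cc2ccc(Oc3ccccc3Cl)cc2)S1` has not been measured. Against compound 1 the change is 2-chlorophenyl in place of 4-chlorophenyl on an oxygen on an aromatic ring. Going by the values given here, no measured pair in the set isolates this kind of change, so no step of known size can be carried over; the ether oxygen itself is kept, which compound 3 shows matters. The expected step from compound 1 to compound 4 is a 1.5-fold higher number from compound 1 to compound 4 (0.16 log units; within the scatter), a modest move, with the direction uncertain. Compound 4 is estimated at 350 nM in this assay, with a range from 100 nM to 1200 nM.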

Compound 4, half-maximal effective concentration: 1190 nM
Estimate against measurement, compound 4: 3.4-fold (0.53 log units) below; the range from low to high includes it.
By their numbers in this assay, from the lowest: compound 2; then compound 1; then compounds 4 and 3 (each within the scatter of the next).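

In this assay, 2-chlorophenyl in place of 4-chlorophenyl on an oxygen on an aromatic ring gives a 5.0-fold higher number from compound 1 to compound 4 (0.70 log units; beyond the scatter) with the ether oxygen and the shared core untouched. Going by these compounds alone, this is the first step between compounds that differ in one place, and the group that leaves and the group that enters have the same atoms and the same ring. The place of the chlorine on this aryl is therefore enough on its own to move the number beyond the scatter, and nothing measured here accounts for the step.

Still open, from the compounds shown here alone, is whether this step belongs to chlorine alone or also appears with a fluorophenyl or methoxyphenyl group on the same oxygen. An unsubstituted phenyl ether would show what either placing of the chlorine contributes.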